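A few compounds are considered here, and "the series" means these few. Any claim that something is new, unique, unknown or untested is made for them only; others in the source may bear on it.

Two compounds of the series carry results in a functional assay on HCT-15 cells (Homo sapiens) for cytotoxicity; on this read-out higher numbers stand for weaker inhibition and lower numbers for stronger inhibition. Compound 1 `C=C1C[C@@H](OC(C)=O)[C@@H](C(C)C)[C@@H]2[C@@H](C(C)=O)[C@@H](OC(=O)/C(C)=C\C)C[C@@H]12` gives 43600 nM in this assay. Compound 2 `C/C=C(/C)C(=O)O[C@H]1C[C@@H](O)C2=CC(=O)C(=C(C)C)C[C@]2(C)[C@H]1C` gives > 100000 nM in this assay, which is a limit of the assay and not a number, the situation described by the limit of > 100000 nM in this assay, at which 1 of the 2 values shown sits. Compound 3 `C/C=C(/C)C(=O)O[C@H]1C[C@@H](OC(=O)/C(C)=C/C)C2=CC(=O)C(=C(C)C)C[C@]2(C)[C@H]1C` differs from compound 2 by (1-methylprop-1-en-1-yl)carbonyl in place of hydrogen on an oxygen on a saturated carbon. Within the data shown here, no step between two measured compounds is known, so the data give no direction for this change; a gain in this assay beyond the scatter is thought possible, not assured. Compound 3 is expected to give 60000 nM, with a range from 20000 nM to 200000 nM. The expected step reads an at least 1.6-fold lower number from compound 2 to compound 3 (0.22 log units; that floor lies within the scatter).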

Compound 3, half-maximal inhibitory concentration: 12800 nM
Compound 3: the middle estimate sits 4.7-fold (0.67 log units) above what was measured; the measured number lies below the stated range.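

With (1-methylprop-1-en-1-yl)carbonyl in place of hydrogen on the oxygen on a saturated carbon, this position now has a direction in this assay: an at least 7.8-fold lower number from compound 2 to compound 3 (0.89 log units; beyond the scatter). Going from hydroxy to ((1-methylprop-1-en-1-yl)carbonyl)oxy therefore moves the series towards stronger inhibition, on this single pair. The value of compound 2 is a limit of the assay, so the step gives only a floor: the limit of > 100000 nM in this assay, at which 1 of the 3 values shown sits.

As far as these compounds go, it remains open whether this particular acyl group is needed, or whether a longer saturated acyl chain or a methyl ether on the same oxygen would serve as well.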